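Aryl exchange on the sulfur-bound chain carbon: cytotoxicity notes

This account rests on a few compounds, and the source may have more. Where it says the series, first, only, none or still open, it means among the compounds named here.

Measured in an ADME assay on HaCaT cells (Homo sapiens) for cytotoxicity, read by MTT assay, with a stated time of 72 h; on this read-out lower numbers stand for stronger inhibition and higher numbers for weaker inhibition:
compound 1 `Cc1cc(S(=O)(=O)/N=C(\N)n2nccc2-c2ccccc2)c(SCc2cccc3ccccc23)cc1Cl` gives 11000 nM
compound 2 `Cc1cc(S(=O)(=O)/N=C(\N)n2nccc2-c2ccccc2)c(SCc2ccccc2C)cc1Cl` gives 18000 nM
compound 3 `Cc1cc(S(=O)(=O)/N=C(\N)n2nccc2-c2ccccc2)c(SCc2cccc(C(F)(F)F)c2)cc1Cl` gives 18000 nM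

Compound 3 stands level with compound 2, the pair forming the highest numbers of the three; its nearest neighbour is compound 2 with no change at the digits printed from compound 2 to compound 3 (within the scatter), its furthest compound 1 with a 1.6-fold higher number from compound 1 to compound 3 (0.21 log units; within the scatter). Compound 4 `Cc1cc(S(=O)(=O)/N=C(\N)n2nccc2-c2ccccc2)c(SCc2ccc(Cl)cc2)cc1Cl` differs from compound 3 by 4-chlorophenyl in place of 3-(trifluoromethyl)phenyl on a saturated chain carbon bound to a sulfur. All three measured steps exchange the aryl on this same carbon: a 1.6-fold higher number from compound 1 to compound 2 (0.21 log units; within the scatter), a 1.6-fold higher number from compound 1 to compound 3 (0.21 log units; within the scatter) and no change at the digits printed from compound 2 to compound 3 (within the scatter), none beyond the scatter. The expectation for compound 4 is therefore no change at the digits printed from compound 3 to compound 4 (within the scatter), no shift beyond the scatter. Compound 4 is estimated at 18000 nM, with a range from 9000 nM to 36000 nM.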

Compound 4, half-maximal inhibitory concentration: 12000 nM
Estimate against measurement, compound 4: 1.5-fold (0.18 log units) above; the range from low to high includes it.
By their numbers in this assay, from the lowest: compounds 1, 4, 2 and 3 (each within the scatter of the next).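

In this assay, the 4-chlorophenyl group gives a 1.5-fold lower number from compound 3 to compound 4 (0.18 log units; within the scatter) and a 1.5-fold lower number from compound 2 to compound 4 (0.18 log units; within the scatter) and also a 1.1-fold higher number from compound 1 to compound 4 (0.04 log units; within the scatter) on the saturated chain carbon bound to a sulfur. With this chlorine-bearing ring, four aryl groups at this position now show no step beyond the scatter, so the read-out does not separate them. No measurement at hand explains these numbers.

Still open, as far as these compounds go, is whether any group at this carbon moves the number beyond the scatter. A carboxylic acid or an amine in place of the aryl would test this.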